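The source may report more compounds than this note shows. Statements on the series, on what has been measured and on what is new or still open speak of the compounds shown alone.

Of the compounds shown here, three built on a shared core have so far been measured in an ADME assay on HS27 cells (Homo sapiens) for antiproliferative activity, read by MTT assay, with a stated time of 24 h; on this read-out higher numbers stand for weaker inhibition and lower numbers for stronger inhibition. Compound 1 `Nc1ncnc2c1ccn2-c1ccc(NC(=O)c2cccc(C(F)(F)F)c2)cc1` gives 7100 nM in this assay. Compound 2 `O=C(Nc1ccc(-n2ccc3c(NC(=O)c4ccccc4)ncnc32)cc1)c1ccc(Cl)c(Cl)c1` gives 5000 nM in this assay, and compound 3 `O=C(Nc1ccc(-n2ccc3c(NC(=O)c4ccccc4)ncnc32)cc1)Nc1ccc(Cl)c(Cl)c1` gives 4500 nM in this assay. Compound 3 has the lowest of the three numbers, but its nearest neighbour compound 2 and even compound 1 sit within the usual scatter of it, so none of the three can be called stronger or weaker than another.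

Compound 4 `O=C(Nc1ccc(-n2ccc3c(NC(=O)c4ccccc4)ncnc32)cc1)c1cccc(C(F)(F)F)c1` has not yet been measured. It differs from compound 3 in one place: 3-(trifluoromethyl)phenyl in place of (3,4-dichlorophenyl)amino on a carbonyl carbon. Within the data shown here, only one measured step speaks to this kind of change, the one from compound 2 to compound 3, which was a 1.1-fold lower number from compound 2 to compound 3 (0.05 log units; within the scatter), where the same carbonyl carbon swapped between an aryl group and an arylamino group with no shift beyond the scatter. With so little to go on, no step beyond the scatter is expected in this assay for compound 4; the step from compound 3 to compound 4 is estimated at a 1.2-fold higher number from compound 3 to compound 4 (0.09 log units; within the scatter). Compound 4 is therefore expected to give about 5500 nM in this assay, with a likely range from 2500 nM to 12000 nM.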

Compound 4, half-maximal inhibitory concentration: 5900 nM
Compound 4: the middle estimate sits 1.1-fold (0.03 log units) below what was measured; the measured number falls inside the stated range.
By their numbers in this assay, from the lowest: compounds 3, 2, 4 and 1 (each within the scatter of the next).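

On the carbonyl carbon, 3-(trifluoromethyl)phenyl in place of (3,4-dichlorophenyl)amino gives a 1.3-fold higher number from compound 3 to compound 4 (0.12 log units; within the scatter) in this assay and thus removes the hydrogen-bond donor of that group without a step beyond the scatter. Replacing 3,4-dichlorophenyl with 3-(trifluoromethyl)phenyl at the same place gives a 1.2-fold higher number from compound 2 to compound 4 (0.07 log units; within the scatter) and adds a second aryl pattern there, while benzoyl in place of hydrogen on the nitrogen on an aromatic ring gives a 1.2-fold lower number from compound 1 to compound 4 (0.08 log units; within the scatter) and so shows that this second site can also change with no step beyond the scatter. Nothing available here explains why these numbers stay so close.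

Open, on these data alone, is whether a group without an aromatic ring on that carbonyl carbon, such as a cyclohexyl ring or a morpholine, would give a step beyond the scatter. Equally open, as far as these compounds go, is whether an acetyl group in place of benzoyl on that nitrogen would do so.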